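Ethoxy to trifluoromethoxy: an expected plasma binding value

The source may hold more compounds than are shown below. What is called first, only, known or untested is meant among the compounds shown, and "the series" means these compounds.

Compound 1 `C=CCOc1ccc(C2CC(=O)Nc3nc(N)[nH]c(=O)c32)cc1OC`: 69.6%
Compound 2 `CCOc1cccc(C2CC(=O)Nc3nc(N)[nH]c(=O)c32)c1`: 65.5%

In an ADME assay on a cell-free system (plasma, Homo sapiens) for protein binding, read by LC-MS, with a stated time of 5 h, compound 2 gives 65.5% and compound 1 gives 69.6% and these two values lie within the scatter of each other. Compound 3 `Nc1nc2c(c(=O)[nH]1)C(c1cccc(OC(F)(F)F)c1)CC(=O)N2` has not yet been measured. It differs from compound 2 by trifluoromethyl in place of ethyl on an oxygen on an aromatic ring and thus by ethoxy to trifluoromethoxy. Going by the values given here, no measured pair shows this change. A small move toward more bound compound is expected in this assay and none clearly beyond the scatter. The expected step a 1.4-fold lower unbound fraction from compound 2 to compound 3 (0.14 log units; within the scatter) is of that size. For compound 3 the estimate is 75% with 60% to 88% as its expected range.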

Compound 3, plasma protein binding: 89%
Compound 3: the middle estimate sits 2.3-fold (0.36 log units) (unbound fraction) above what was measured, and the stated range ends below it.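

A step of a 3.1-fold lower unbound fraction from compound 2 to compound 3 (0.50 log units; beyond the scatter) in this assay shows that the group on this oxygen on an aromatic ring can shift plasma protein binding beyond the scatter when trifluoromethyl takes the place of ethyl. The earlier compounds shown here showed no step that differed in one place, so they could not reveal this. No evidence at hand bears on the reason for the step. The compounds shown leave open whether a methyl group, a longer chain or a hydroxyl group at this oxygen would bring a comparable shift. They also leave open whether the same change would have this effect on the core of compound 1.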